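Hexyl to isopropyl on an aromatic ring oxygen

A few compounds are considered here, and "the series" means these few. Any claim that something is new, unique, unknown or untested is made for them only; others in the source may bear on it.

In a functional assay on DU-145 cells (Homo sapiens) for antiproliferative activity, read by WST assay, with a stated time of 3 days (on this read-out higher numbers stand for weaker inhibition and lower numbers for stronger inhibition), compound 1 (`CCOc1c(-c2cc(OC)c(OC)c(OC)c2)oc2ccccc2c1=O`) gives 6200 nM as a measured number. Compound 2 (`CCCCOc1c(-c2cc(OC)c(OC)c(OC)c2)oc2ccccc2c1=O`) reads > 50000 nM as a limit of the assay and not a number. Compound 3 (`CCCCCCOc1c(-c2cc(OC)c(OC)c(OC)c2)oc2ccccc2c1=O`) also reads > 50000 nM as a limit and not a number.

Compound 4 (`COc1cc(-c2oc3ccccc3c(=O)c2OC(C)C)cc(OC)c1OC`) departs from compound 3 by isopropyl in place of hexyl on an oxygen on an aromatic ring and so carries isopropyl in place of hexyl on an oxygen on an aromatic ring. The measured steps that bear on this are an at least 8.0-fold higher number from compound 1 to compound 2 (0.90 log units; beyond the scatter) and an at least 8.0-fold higher number from compound 1 to compound 3 (0.90 log units; beyond the scatter) and both lie beyond the scatter. Also shown is a step that the two limits leave unreadable from compound 2 to compound 3 and it adds no size.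

For the measured compounds named here, compound 1 with 6200 nM holds the only number measured, and the chain of compound 4 is shorter than hexyl, so a partial return toward that level is expected. The expected move is an at least 3.3-fold lower number from compound 3 to compound 4 (0.52 log units; beyond the scatter) and it points toward a lower number and stronger inhibition. The estimate for compound 4 is 15000 nM with an expected range from 4000 nM to 50000 nM in this read-out.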

Compound 4, half-maximal inhibitory concentration: > 50000 nM
Compound 4: only a limit was reported (the forecaster's own chance of this, stated with the estimate: 30%); at least 3.3-fold (0.52 log units) between middle value and limit.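

In this assay compound 4 reads > 50000 nM, which is a limit of the assay and not a number. Cutting hexyl back to isopropyl on this oxygen therefore recovers no measurable inhibition, so a shorter chain alone does not return the series to a measured value. Methyl in place of hydrogen on the saturated chain carbon bound to the oxygen gives an at least 8.0-fold higher number from compound 1 to compound 4 (0.90 log units; beyond the scatter), so this single branching change already reaches the limit, and the steps among the other compounds cannot be read: the limit of > 50000 nM in this assay, at which 3 of the 4 values shown sit.

From the compounds shown here alone, how a straight propyl or a methyl on this oxygen would read remains open, and so does whether an amine at the end of the ethyl chain would keep a measurable value. Going by these compounds, how far the butyl, hexyl and isopropyl compounds differ from one another also stays unknown.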